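The source may report more compounds than this note shows. Statements on the series, on what has been measured and on what is new or still open speak of the compounds shown alone.

Measured compounds:

Compound 1, `COc1ccc(C2=NN(C(=O)c3ccc4c(c3)OCCO4)C(c3ccc(F)cc3)C2)cc1` — 3780 nM
Compound 2, `COc1ccc(C2=NN(C(=O)c3ccc4c(c3)OCCO4)C(c3ccccc3F)C2)cc1` — 3470 nM
Compound 3, `O=C(c1ccc2c(c1)OCCO2)N1N=C(c2ccc(Br)cc2)CC1c1ccc(F)cc1` — 3260 nM

All three were tested in a functional assay on WM 266-4 cells (Homo sapiens) for inhibition, read by MTT assay, with a stated time of 24 h; on this read-out higher numbers stand for weaker inhibition of growth and lower numbers for stronger inhibition of growth. The three values sit close together. Compound 1 differs from compound 2 only in 2-fluorophenyl in place of 4-fluorophenyl on a saturated ring carbon, and that change gave a 1.1-fold lower number from compound 1 to compound 2 (0.04 log units; within the scatter). Compound 1 differs from compound 3 in bromo in place of methoxy on an aromatic carbon, and that change gave a 1.2-fold lower number from compound 1 to compound 3 (0.06 log units; within the scatter). Neither step reaches beyond the scatter, so the three compounds cannot be ranked against one another on these numbers.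

Compound 4, `O=C(c1ccc2c(c1)OCCO2)N1N=C(c2ccc(Br)cc2)CC1c1ccccc1F`, has not yet been measured in this assay. It differs from compound 3 by 2-fluorophenyl in place of 4-fluorophenyl on a saturated ring carbon. This is the same kind of change as that from compound 1 to compound 2, but not the same: in compound 1 the place is two ring bonds from the ring atom that bears a 4-methoxyphenyl group, whereas in compound 3 it is two ring bonds from the ring atom that bears a 4-bromophenyl group. The two cores themselves differ by bromo in place of methoxy on an aromatic carbon.

For compound 4 the expected step is a 1.1-fold lower number from compound 3 to compound 4 (0.04 log units; within the scatter), which rests on the step of a 1.1-fold lower number from compound 1 to compound 2 (0.04 log units; within the scatter) seen in this assay for the same kind of change. Compound 4 is therefore expected to give about 3000 nM in this assay, estimated to lie between 1500 nM and 6000 nM.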

Compound 4, concentration for 50% growth inhibition: 580 nM
Compound 4: middle estimate off by 5.2-fold (0.71 log units), on the high side; the whole stated range lies above it.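

In this assay, 2-fluorophenyl in place of 4-fluorophenyl on the saturated ring carbon gave a 5.6-fold lower number from compound 3 to compound 4 (0.75 log units; beyond the scatter) on the core that carries the 4-bromophenyl group, and this step does not match the one seen on the core that carries the 4-methoxyphenyl group: the same change on two cores in this assay, a 1.1-fold lower number (0.04 log units; within the scatter) from compound 1 to compound 2 and a 5.6-fold lower number (0.75 log units; beyond the scatter) from compound 3 to compound 4, 5.2-fold (0.71 log units) apart, beyond the scatter of two such steps. Read the other way round, bromo in place of methoxy gave a 6.0-fold lower number from compound 2 to compound 4 (0.78 log units; beyond the scatter) when the 2-fluorophenyl group was present, and this too differs from the step seen with the 4-fluorophenyl group: the same change on two cores in this assay, a 1.2-fold lower number (0.06 log units; within the scatter) from compound 1 to compound 3 and a 6.0-fold lower number (0.78 log units; beyond the scatter) from compound 2 to compound 4, 5.2-fold (0.71 log units) apart, beyond the scatter of two such steps. So neither change could be carried unaltered from one core to the other in this series, as the size of each step depended on the group present at the other place, but these four compounds form a single such comparison, which gives no general rule for other cores and does not show what lies behind the difference.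

The compounds shown leave open whether the large step with the 2-fluorophenyl group is particular to bromo or would also appear with chloro, methyl or an amine in its place. They also leave open whether a chlorophenyl group or an unsubstituted phenyl group on the saturated ring carbon would behave like the 2-fluorophenyl group on the same core.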